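One Ring Group Exchanged on Compound 1

This account rests on a few compounds, and the source may have more. Where it says the series, first, only, none or still open, it means among the compounds named here.

Exposure after an oral dose is a whole-animal result, so the effect of one structural change is hard to foresee. In an ADME assay on the whole organism (Rattus norvegicus) for pharmacokinetics, at a dose of 10 mg/kg by the oral route (on this read-out higher numbers stand for higher exposure at the dose given and lower numbers for lower exposure), compound 1 (`COc1cc(N2CCC(C)(O)CC2)ccc1Nc1nc(O[C@H]2CCOC(C)(C)C2)c2cc[nH]c2n1`) gives 5300 ng.h/mL. The only other measured molecule, compound 2 (`CN(C)C(=O)c1ccc(Nc2nc(O[C@H]3CC[C@@](C)(O)CC3)c3cc[nH]c3n2)c(OCC(F)(F)F)c1`), gives 8170 ng.h/mL. For the measured compounds named here, these two numbers lie within the scatter of each other, so compound 1 stands level with the only available comparison.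

Compound 3 (`COc1cc(N2CCN(C3COC3)CC2)ccc1Nc1nc(O[C@H]2CCOC(C)(C)C2)c2cc[nH]c2n1`) keeps the core of compound 1 but carries 4-(oxetan-3-yl)piperazin-1-yl in place of 4-hydroxy-4-methylpiperidin-1-yl, on an aromatic carbon meta to a methoxy group. The counted difference is 4-(oxetan-3-yl)piperazin-1-yl in place of 4-hydroxy-4-methylpiperidin-1-yl on an aromatic carbon.

Going by the values given here, no measured pair shows what an exchange like this does in this assay, and compound 2 differs from compound 1 in more than one place, so it offers no guide to direction. The expected change is therefore small, with no shift beyond the scatter, and the estimated step is a 1.3-fold lower number from compound 1 to compound 3 (0.12 log units; within the scatter). With so little to go on, the range is wide. Compound 3 is expected to give about 4000 ng.h/mL, within a range from 1200 ng.h/mL to 12000 ng.h/mL.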

Compound 3, area under the concentration-time curve: 12200 ng.h/mL
Beside the measured number, compound 3's estimate is 3.1-fold (0.48 log units) below it; measured number above the stated range.
By their numbers in this assay, from the lowest: compounds 1, 2 and 3 (each within the scatter of the next, the first and the last beyond it).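

For the compounds shown here, putting 4-(oxetan-3-yl)piperazin-1-yl in place of 4-hydroxy-4-methylpiperidin-1-yl gives the first comparison in this assay between two molecules that differ in only one place, and it reads a 2.3-fold higher number from compound 1 to compound 3 (0.36 log units; beyond the scatter) on this scale. The group on this aromatic carbon, meta to a methoxy group and para to a large group, can therefore shift oral exposure in the rat by a modest amount beyond the usual scatter, even with the rest of compound 1 left unchanged. The entering group has a second ring and no hydrogen-bond donor, but no measurement here connects either feature to the higher exposure, and the pair gives a direction without a cause.

The compounds shown leave open whether the rise belongs to the piperazine ring, the oxetane ring or the two together, and a 4-methylpiperazin-1-yl group at the same carbon would help to separate these possibilities. The result also rests on a single pair, leaving open whether the same exchange would raise exposure on a different molecule.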